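The source may hold more compounds than are shown below. What is called first, only, known or untested is meant among the compounds shown, and "the series" means these compounds.

Compound 1 `O=C(O)c1ccccc1-c1ccc(CCc2ncc(Cc3cccc(F)c3)[nH]2)cc1` — in an in vitro functional assay on cells for agonist activity at Bombesin receptor subtype-3 (Homo sapiens), read by luminescence and calcium flux (on this read-out lower numbers stand for an effect already at smaller amounts and higher numbers for an effect only at larger amounts of compound), compound 1 gives 159 nM.
Compound 2 `O=C(O)c1ccccc1-c1ccc(CCc2ncc(CCC3CCCCC3)[nH]2)cc1` — in this assay compound 2 gives 642 nM.

Among the measured compounds shown here, compound 2 stands at the higher of the two numbers measured so far; its nearest neighbour is compound 1, and the single measured step, a 4.0-fold higher number from compound 1 to compound 2 (0.61 log units; beyond the scatter), is the only change in this small set.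

Compound 3 `CC(C)CCc1cnc(CCc2ccc(-c3ccccc3C(=O)O)cc2)[nH]1` has not yet been measured. It differs from compound 2 by isopropyl in place of cyclohexyl on a saturated chain carbon, two bonds along the chain from an aromatic carbon. For the measured compounds named here, the one measured step bears on this only loosely: it exchanged a fluorinated aromatic ring for a saturated ring on the same chain, whereas the step from compound 2 to compound 3 exchanges one saturated carbon group for a smaller one and no aromatic group is involved. Going by the values given here, no measured pair shows what shrinking the cyclohexyl to isopropyl does here, so the expectation rests on the modest size of the change itself rather than on a matching precedent. The number for compound 3 is therefore expected to stay close to that of compound 2, with a step of about a 1.2-fold higher number from compound 2 to compound 3 (0.10 log units; within the scatter), which is not expected to exceed the scatter. The estimate for compound 3 in this assay is 800 nM, with a range from 300 nM to 2500 nM.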

Compound 3, half-maximal effective concentration: 119 nM
Compound 3: the middle estimate sits 6.7-fold (0.83 log units) above what was measured; the whole stated range lies above it.
By their numbers in this assay, from the lowest: compounds 3 and 1 (each within the scatter of the next); then compound 2.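

In this assay, the exchange of cyclohexyl for isopropyl on a saturated chain carbon, two bonds along the chain from an aromatic carbon, gives a 5.4-fold lower number from compound 2 to compound 3 (0.73 log units; beyond the scatter) and so runs opposite to what a small change might suggest: this position responds clearly to a group of 3 heavy atoms with no ring in place of one of 6 heavy atoms with a ring. The exchange of 3-fluorophenyl for isobutyl gives a 1.3-fold lower number from compound 1 to compound 3 (0.13 log units; within the scatter), so an aromatic ring is not needed on this chain to reach the level of compound 1, and compound 2 now stands apart from both other compounds, with steps to each beyond the scatter. Nothing measured here gives a reason for this difference.

The compounds shown leave open whether a smaller saturated ring on the same chain, such as cyclopropyl or cyclopentyl, would read like compound 3 or like compound 2. They also leave open how a longer chain, or an amine or hydroxyl group at the end of the isopentyl chain, would fare in this assay.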